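The source may report more compounds than this note shows. Statements on the series, on what has been measured and on what is new or still open speak of the compounds shown alone.

Measured compounds in an assay on isolated protein for inhibition of thiosulfate sulfurtransferase (Homo sapiens); a higher number here means a weaker inhibitor, a lower number a stronger inhibitor:

Compound 1 `O=S(=O)(Nc1ccc(-c2nc3cc(NS(=O)(=O)c4ccccc4Cl)ccc3o2)cc1)c1ccccc1Cl` gives > 100000 nM, a limit of the assay.

Compound 2 `COc1ccc(S(=O)(=O)Nc2ccc3oc(-c4ccc(NC(=O)c5cccc(C)c5[N+](=O)[O-])cc4)nc3c2)cc1` gives > 100000 nM, a limit of the assay.

Compound 3 `O=S(=O)(Nc1ccc(-c2nc3cc(NS(=O)(=O)c4cccc5ccccc45)ccc3o2)cc1)c1cccc2ccccc12` gives > 100000 nM, a limit of the assay.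

Compound 2 thus stands at a limit and not at a number, and the two other values in this assay are limits as well: the limit of > 100000 nM in this assay, at which 3 of the 3 values shown sit. Going by the values given here, no step between two measured compounds is resolved, so nothing in the set yet tells which change moves the read-out.

The unmeasured compound 4 `COc1ccc(S(=O)(=O)Nc2ccc3oc(-c4ccc(NS(=O)(=O)c5cc(Br)ccc5OC)cc4)nc3c2)cc1` differs from compound 2 in one place: (5-bromo-2-methoxyphenyl)sulfonyl in place of (3-methyl-2-nitrophenyl)carbonyl on a nitrogen on an aromatic ring. The shared core and the (4-methoxyphenyl)sulfonyl amine on its other side are unchanged. Compound 1 and compound 3 already carry an arylsulfonyl amine on the same nitrogen and both sit at the limit, so the sulfonyl-for-carbonyl exchange in compound 4 gives no ground to expect an increase in inhibition beyond the scatter; the expected step from compound 2 to compound 4 in this assay is a step that the limit leaves unreadable from compound 2 to compound 4, that is, none that this assay would resolve. For compound 4 the estimated half-maximal inhibitory concentration is 150000 nM, with a range from 40000 nM to 500000 nM, and a limit rather than a number is the more likely outcome.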

Compound 4, half-maximal inhibitory concentration: > 100000 nM
Compound 4: only a limit was reported; the forecaster's own chance of this, stated with the estimate: 80%; the middle value is on the limit's open side.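

In this assay compound 4 gives > 100000 nM, a limit of the assay. Compound 2 also stands at a limit, so no step from compound 2 to compound 4 can be read: the limit of > 100000 nM in this assay, at which 4 of the 4 values shown sit.

The compounds shown leave open which change in one place, if any, would give a number rather than a limit in this assay.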